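The compounds below may be only part of what the source reports. "The series", "measured", "known", "first", "only" and "open" are said of these compounds alone.

Going by the values given here, compound 1 `CC(C)(C)OC(=O)N1CCN(C(=O)Nc2ccc([N+](=O)[O-])cc2)C(c2ccccc2)C1` stands as the less toxic of the two compounds measured so far: in an ADME assay on A549 cells (Homo sapiens) for cytotoxicity, read by resazurin assay, with a stated time of 48 h (on this read-out lower numbers stand for higher toxicity in this test and higher numbers for lower toxicity in this test), compound 1 gives 161000 nM, the higher of the two numbers. Compound 2 `CC(C)(C)OC(=O)N1CCN(C(=O)Nc2ccc(C(F)(F)F)cc2)C(c2ccccc2)C1` differs from it on one aromatic carbon only, and in this assay compound 2 gives 42100 nM. The step of a 3.8-fold lower number from compound 1 to compound 2 (0.58 log units; beyond the scatter) shows that exchanging the nitro group there moved the number downward, toward greater toxicity, by a modest amount. Compound 3 `Cc1ccc(NC(=O)N2CCN(C(=O)OC(C)(C)C)CC2c2ccccc2)cc1` carries the change (methyl in place of nitro on an aromatic carbon). Among the compounds with values here, the only measured comparison that bears on this change is a 3.8-fold lower number from compound 1 to compound 2 (0.58 log units; beyond the scatter), so a similar modest downward step is expected for compound 3, though a methyl group is not a trifluoromethyl group and the step could also end within the scatter. The estimate for compound 3 in this assay is 80000 nM, with a range from 30000 nM to 200000 nM. This corresponds to an expected step of a 2.0-fold lower number from compound 1 to compound 3 (0.30 log units; within the scatter).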

Compound 3, half-maximal cytotoxic concentration: 165000 nM
Compound 3: middle estimate off by 2.1-fold (0.31 log units), on the low side; the measured number falls inside the stated range.
By their numbers in this assay, from the lowest: compound 2; then compounds 1 and 3 (each within the scatter of the next).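

At this place on the aromatic ring, para to a large group, nitro and methyl give numbers within the scatter of each other in this assay, with a 1.0-fold higher number from compound 1 to compound 3 (0.01 log units; within the scatter). Replacing nitro here therefore does not by itself bring the lower number seen with trifluoromethyl, and the comparison between the two replacement groups gives a 3.9-fold higher number from compound 2 to compound 3 (0.59 log units; beyond the scatter), which sets compound 2 apart from compound 1 and compound 3. No measurement at hand accounts for this difference between trifluoromethyl and the other two groups. Still open, going by these compounds, is whether a chlorine, an amine or a carboxylic acid on this carbon would fall with compound 2 or with the other two compounds. On these data alone, a longer chain in place of methyl is equally open.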